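Amino in Place of Fluoro: an Untested Analogue

The source may report more compounds than this note shows. Statements on the series, on what has been measured and on what is new or still open speak of the compounds shown alone.

Of the compounds shown here, two have been measured in an ADME assay on L02 cells (Homo sapiens) for inhibition, read by MTT assay, with a stated time of 48 h, tested at 100 uM; a higher number here means more inhibition at the concentration tested (going by the name of the read-out), a lower number less inhibition. Compound 1 `O=c1nc(-c2ccc(F)cc2)ss1` gives 33.7%, the highest of the two numbers, while compound 2 `O=c1nc(-c2ccc([N+](=O)[O-])cc2Cl)ss1` gives 28.6%, a value within the scatter of compound 1, so the two cannot be ordered. Compound 3 `Nc1ccc(-c2nc(=O)ss2)cc1` has not yet been tested. It differs from compound 1 in one place: amino in place of fluoro on an aromatic carbon. Among the compounds with values here, no step between measured compounds is available, and nothing points to a change beyond the scatter in either direction. Compound 3 is therefore expected to give 30% in this assay, with a range from 15% to 45%, the step of a number 3.7 percentage points lower from compound 1 to compound 3 (within the scatter) expected to stay within the scatter.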

Compound 3, a percentage reported as inhibition, at one concentration (the size of the read-out at that concentration, not a potency): 46.3%
Compound 3: middle estimate off by 16.3 percentage points, on the low side; measured number above the stated range.
By their numbers in this assay, from the lowest: compounds 2 and 1 (each within the scatter of the next); then compound 3.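

Amino in place of fluoro on an aromatic carbon gives a number 12.6 percentage points higher from compound 1 to compound 3 (beyond the scatter) in this assay, so a single change at this position can move the number beyond the scatter. Compound 1 and compound 2 had shown no such separation, and no step at this position had been available. No evidence at hand accounts for this step. The compounds shown leave open whether a hydroxyl or a dimethylamino group in the same place would give a similar number, and whether a longer amine would carry the step further.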